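The source may hold more compounds than are shown below. What is called first, only, known or untested is meant among the compounds shown, and "the series" means these compounds.

Measured compounds in a functional assay on CHO cells for antagonist activity at Orexin/Hypocretin receptor type 1 (Homo sapiens), read by FLIPR and calcium flux; on this read-out higher numbers stand for weaker inhibition and lower numbers for stronger inhibition:
compound 1 `CCn1nc(C)c2c1CCN(C(C(=O)NC)c1ccccc1)C2CCc1cccc(C(F)(F)F)c1` gives 358 nM
compound 2 `CCn1nc(C)c2c1CCN(C(C(=O)NC)c1ccccc1)C2CCc1ccccc1F` gives 669 nM
compound 3 `CCn1nc(C)c2c1CCN(C(C(=O)NC)c1ccccc1)C2CCc1ccc(C)cc1` gives 108 nM

Compound 3 stands lowest of the three numbers; the step of a 3.3-fold lower number from compound 1 to compound 3 (0.52 log units; beyond the scatter) and the step of a 6.2-fold lower number from compound 2 to compound 3 (0.79 log units; beyond the scatter) both lie beyond the scatter, while a 1.9-fold higher number from compound 1 to compound 2 (0.27 log units; within the scatter) does not.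

Compound 4 `CCn1nc(C)c2c1CCN(C(C(=O)NC)c1ccccc1)C2CCc1ccc(OC)cc1` carries methoxy in place of methyl on an aromatic carbon. Among the compounds with values here, no measured step exchanges methyl for methoxy; the steps that bear on the aryl substitution, from compound 1 to compound 3 and from compound 2 to compound 3, each exchange a whole substitution pattern and were modest. A like exchange of one group for one near in size at the same position is expected to give at most a small step in this assay, in no sure direction, likely within the scatter: a 1.4-fold higher number from compound 3 to compound 4 (0.14 log units; within the scatter).

Compound 4 is therefore expected near 150 nM, between 60 nM and 400 nM.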

Compound 4, half-maximal inhibitory concentration: 10000 nM
The estimate for compound 4 lay 67-fold (1.82 log units) below the measured number; the whole stated range lies below it.
By their numbers in this assay, from the lowest: compound 3; then compounds 1 and 2 (each within the scatter of the next); then compound 4.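

In this assay, within the data shown here, the aryl end of the chain proves far less tolerant than the earlier compounds showed: methoxy in place of methyl on an aromatic carbon, para to a large group, gives the largest step (a 93-fold higher number from compound 3 to compound 4 (1.97 log units; beyond the scatter)). The 4-methoxyphenyl group also stands apart from the other two aryl groups (a 15-fold higher number from compound 2 to compound 4 (1.17 log units; beyond the scatter); a 28-fold higher number from compound 1 to compound 4 (1.45 log units; beyond the scatter)), so this one exchange outweighs the differences among the earlier substitution patterns. No evidence at hand gives a reason for this step.

Still open, going by these compounds, is whether ethyl, hydroxy or a chlorine atom at this same place behaves like methyl or like methoxy. Also open, on these data alone, is whether methoxy elsewhere on the aromatic ring gives a step of similar size.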